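Homologation of an alkoxy chain on a benzanilide acid

This account rests on a few compounds, and the source may have more. Where it says the series, first, only, none or still open, it means among the compounds named here.

Measured compounds:
compound 1 `CC(Oc1cccc(NC(=O)c2ccc(Oc3ccccc3)cc2)c1)C(=O)O` — > 10000 nM
compound 2 `CC(C)(Oc1cccc(NC(=O)c2ccc(Oc3ccccc3)cc2)c1)C(=O)O` — > 10000 nM
compound 3 `CCCOc1cccc(C(=O)Nc2cccc(C(=O)O)c2)c1` — 2150 nM

In an assay on isolated protein for agonist activity at Bile acid receptor (Homo sapiens), read by TR-FRET, with a stated time of 3 h, in the absence of a further agent (on this read-out higher numbers stand for an effect only at larger amounts of compound and lower numbers for an effect already at smaller amounts), compound 1 gives > 10000 nM, which is a limit of the assay rather than a number. Compound 2 likewise gives > 10000 nM, again a limit. Compound 2 differs from compound 1 by methyl in place of hydrogen on a saturated chain carbon bound to a carbonyl carbon, an oxygen on an aromatic ring and a saturated chain carbon; the step that the two limits leave unreadable from compound 1 to compound 2 cannot be read because both values sit at the limit of > 10000 nM in this assay, at which 2 of the 3 values shown sit. Going by the values given here, compound 3 gives 2150 nM in this assay, the only true number among the three. The difference between the core of compound 3 and that of compound 1 is not broken down here.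

Compound 4 `CCCCOc1cccc(C(=O)Nc2cccc(C(=O)O)c2)c1` has not yet been measured. It differs from compound 3 by methyl in place of hydrogen on a saturated chain carbon, three bonds along the chain from an oxygen on an aromatic ring, the same kind of change as from compound 1 to compound 2, though the place differs: there the carbon was bound to a carbonyl carbon, an oxygen on an aromatic ring and a saturated chain carbon; here it lies three bonds along the chain from an oxygen on an aromatic ring. Because the earlier step that the two limits leave unreadable from compound 1 to compound 2 stands at a limit, it offers no guide. The expected step of a 1.4-fold lower number from compound 3 to compound 4 (0.16 log units; within the scatter) is therefore kept modest, resting only on the value of compound 3, 2150 nM. Compound 4 is estimated at 1500 nM, with a likely range from 500 nM to 5000 nM.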

Compound 4, half-maximal effective concentration: 3150 nM
For compound 4 the middle estimate is 2.1-fold (0.32 log units) below the measured one, within the range that was stated.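

In this assay, propyl to butyl on the core of compound 3 gives a 1.5-fold higher number from compound 3 to compound 4 (0.17 log units; within the scatter), so on this core the added methyl, three bonds along the chain from an oxygen on an aromatic ring, leaves the value within the scatter. The methyl step on the core of compound 1 cannot be read, because compound 1 and compound 2 both stand at a limit of the assay: the limit of > 10000 nM in this assay, at which 2 of the 4 values shown sit. The series therefore shows the effect of this change on one core only and does not show whether it carries over to another, where the methyl also sits at a different place.

On these data alone, it remains open whether a longer chain, such as pentyl, would move the value on the core of compound 3 beyond the scatter. As far as these compounds go, it also remains open how a tetrazole in place of the carboxylic acid would read on that core.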